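Amide aryl variation: compounds 1 to 4

The source may hold more compounds than are shown below. What is called first, only, known or untested is meant among the compounds shown, and "the series" means these compounds.

Measured in a functional assay on HeLa cells (Homo sapiens) for antiproliferative activity, read by MTT assay, with a stated time of 48 h; a higher number here means a weaker inhibitor, a lower number a stronger inhibitor:
compound 1 `COc1ccc(-c2cn3cc(C4=CCN(C(=O)c5cccc(C(F)(F)F)c5)CC4)ccc3n2)cc1OC`: 4860 nM
compound 2 `COc1ccc(-c2cn3cc(C4=CCN(C(=O)c5ccccc5C(F)(F)F)CC4)ccc3n2)cc1OC`: 7950 nM
compound 3 `COc1ccc(-c2cn3cc(C4=CCN(C(=O)c5ccccc5)CC4)ccc3n2)cc1OC`: 10200 nM

Compound 3 stands at the highest number of the three in this assay. One of its two gaps is a 1.3-fold higher number from compound 2 to compound 3 (0.11 log units; within the scatter), so within the scatter; the other is a 2.1-fold higher number from compound 1 to compound 3 (0.32 log units; beyond the scatter), modest but beyond it.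

Compound 4 `COc1ccc(-c2cn3cc(C4=CCN(C(=O)c5cccs5)CC4)ccc3n2)cc1OC` differs from compound 3 by thiophen-2-yl in place of phenyl on a carbonyl carbon. Within the data shown here, no measured step exchanges the aromatic ring itself; the two steps ending at compound 3 only remove a trifluoromethyl and gave, at most, a modest shift. Nothing here argues for a large move in either direction, so the expected step is a 1.1-fold lower number from compound 3 to compound 4 (0.05 log units; within the scatter), not beyond the scatter. Compound 4 is therefore estimated at 9000 nM, within 4000 nM to 20000 nM.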

Compound 4, half-maximal inhibitory concentration: 16000 nM
Compound 4: the middle estimate sits 1.8-fold (0.25 log units) below what was measured; the range from low to high includes it.
By their numbers in this assay, from the lowest: compounds 1, 2, 3 and 4 (each within the scatter of the next, the first and the last beyond it).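

In this assay, exchanging the aromatic ring itself on the carbonyl carbon gives a 1.6-fold higher number from compound 3 to compound 4 (0.20 log units; within the scatter) and a 2.0-fold higher number from compound 2 to compound 4 (0.30 log units; within the scatter), so neither step separates thiophen-2-yl from the phenyl rings with or without the 2-(trifluoromethyl) group. Only a 3.3-fold higher number from compound 1 to compound 4 (0.52 log units; beyond the scatter) clears the scatter, and that step also removes the 3-(trifluoromethyl) group. No measured evidence accounts for the size of these steps.

From the compounds shown here alone, whether a pyridine ring at this carbonyl carbon would shift the number remains open. So does the effect of an amine or a carboxylic acid on the phenyl ring.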